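The source may hold more compounds than are shown below. What is called first, only, known or untested is meant among the compounds shown, and "the series" means these compounds.

Measured compounds:
- compound 1 `NC[C@@H]1CCCc2cc(S(=O)(=O)c3cc(F)cc4[nH]cnc34)ccc21`; in an assay on isolated protein for displacement of a labelled ligand from 5-hydroxytryptamine receptor 6 (Homo sapiens) (on this read-out lower numbers stand for stronger inhibition and higher numbers for weaker inhibition), compound 1 gives 5.01 nM
- compound 2 `O=S(=O)(c1cccc(F)c1)c1ccc2c(c1)CCC[C@H]2CN1CCCS1(=O)=O`; in this assay compound 2 gives 31.6 nM

Among the measured compounds shown here, compound 2 carries the highest of the two numbers; its only neighbour, compound 1, lies a good deal lower, and that gap is beyond the usual scatter. For the measured compounds named here, no single-point step between measured compounds is available, so the series offers no measured step to lean on.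

Compound 3 `CN(C[C@@H]1CCCc2cc(S(=O)(=O)c3cccc(F)c3)ccc21)C(N)=O` differs from compound 2 in one place: a group of 5 heavy atoms (2 carbon, 2 nitrogen, 1 oxygen; no ring) in place of a group of 7 heavy atoms (3 carbon, 1 nitrogen, 2 oxygen, 1 sulfur; one five-membered non-aromatic ring with 2 hetero atoms), on a saturated chain carbon bound to a saturated ring carbon.

Nothing measured here says how a change of this kind moves the numbers. The working expectation for compound 3 is a step of about nil to modestly weaker, a 1.3-fold higher number from compound 2 to compound 3 (0.10 log units; within the scatter), with a wide band around it. Compound 3 is estimated at 40 nM, within a range from 10 nM to 160 nM.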

Compound 3, inhibition constant: 39.8 nM
Compound 3: the middle estimate sits 1.0-fold (0.00 log units) above what was measured; the measured number falls inside the stated range.
By their numbers in this assay, from the lowest: compound 1; then compounds 2 and 3 (each within the scatter of the next).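

In this assay, the saturated chain carbon bound to a saturated ring carbon takes carbamoyl(methyl)amino in place of the five-membered non-aromatic ring with 2 hetero atoms, with a 1.3-fold higher number from compound 2 to compound 3 (0.10 log units; within the scatter). This position therefore accepts an open-chain group with no ring and no sulfur, and with 1 hydrogen-bond donor where the leaving group has none, without a change beyond the scatter. No available measurement bears on why the two groups read alike.

Compound 1 differs from compound 2 and compound 3 in more than one place, so its lower number cannot be assigned to this position alone. From the compounds shown here alone, whether a carboxylic acid, a morpholine ring or a longer chain at this position would also stay within the scatter of compound 2 remains open.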